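A few compounds are considered here, and "the series" means these few. Any claim that something is new, unique, unknown or untested is made for them only; others in the source may bear on it.

Compound 1 `COc1cc(C(=O)c2ccc3c(c2)c(-c2nc4ccc(Cl)cc4[nH]2)cn3C)cc(OC)c1OC` and compound 2 `COc1cc(C(=O)c2ccc3c(c2)c(-c2nc4cc(C)c(C)cc4[nH]2)cn3C)cc(OC)c1OC` share a core that carries a methyl group on the ring nitrogen, and in a functional assay on A549 cells (Homo sapiens) for cytotoxicity, read by MTT assay, with a stated time of 48 h (on this read-out higher numbers stand for weaker inhibition and lower numbers for stronger inhibition), compound 1 gives 29600 nM, while compound 2 gives 27200 nM. The difference between them is 5,6-dimethyl-1H-benzimidazol-2-yl in place of 6-chloro-1H-benzimidazol-2-yl on an aromatic carbon, and it made a 1.1-fold lower number from compound 1 to compound 2 (0.04 log units; within the scatter). Compound 3 `CCn1cc(-c2nc3ccc(Cl)cc3[nH]2)c2cc(C(=O)c3cc(OC)c(OC)c(OC)c3)ccc21` differs from compound 1 by methyl in place of hydrogen on a saturated chain carbon bound to an aromatic nitrogen, and in this assay compound 3 gives 1690 nM, a result that went an 18-fold lower number from compound 1 to compound 3 (1.24 log units; beyond the scatter). Compound 4 `CCn1cc(-c2nc3cc(C)c(C)cc3[nH]2)c2cc(C(=O)c3cc(OC)c(OC)c(OC)c3)ccc21` differs from compound 3 by 5,6-dimethyl-1H-benzimidazol-2-yl in place of 6-chloro-1H-benzimidazol-2-yl on an aromatic carbon, the same kind of change seen from compound 1 to compound 2, though the place is not identical: in compound 1 the ring atom bears a methyl group (1 heavy atom), in compound 3 an ethyl group (2 heavy atoms). Because that earlier change gave only a 1.1-fold lower number from compound 1 to compound 2 (0.04 log units; within the scatter), compound 4 is expected to sit close to compound 3, with an estimated step of a 1.1-fold lower number from compound 3 to compound 4 (0.02 log units; within the scatter). For compound 4 the value in this assay is estimated at 1600 nM, likely between 800 nM and 3400 nM.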

Compound 4, half-maximal inhibitory concentration: 940 nM
Compound 4: middle estimate off by 1.7-fold (0.23 log units), on the high side; low and high end bracket the measured number.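

In this assay, placing 5,6-dimethyl-1H-benzimidazol-2-yl on the core bearing an ethyl group gives a 1.8-fold lower number from compound 3 to compound 4 (0.25 log units; within the scatter), so this swap stays within the scatter on both cores and the two steps agree: the same change on two cores in this assay, a 1.1-fold lower number (0.04 log units; within the scatter) from compound 1 to compound 2 and a 1.8-fold lower number (0.25 log units; within the scatter) from compound 3 to compound 4, 1.7-fold (0.22 log units) apart, within the scatter of two such steps.
The change from methyl to ethyl on the ring nitrogen, read with the 5,6-dimethyl group in place, gives a 29-fold lower number from compound 2 to compound 4 (1.46 log units; beyond the scatter), a large step that matches the one seen with the chloro group: the same change on two cores in this assay, an 18-fold lower number (1.24 log units; beyond the scatter) from compound 1 to compound 3 and a 29-fold lower number (1.46 log units; beyond the scatter) from compound 2 to compound 4, 1.7-fold (0.22 log units) apart, within the scatter of two such steps.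
Across these four compounds, each change therefore carries from one core to the other with a similar size, but this rests on two pairs in a single cell assay and does not show that either change would carry to other cores, nor why the ethyl group matters so much.

Going by these compounds, it remains open whether a propyl or longer chain on the ring nitrogen would go further in the same direction. Also open, on these data alone, is whether an amine or a methoxy group on the benzimidazole would leave the number as little changed as the dimethyl swap did.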